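The source may hold more compounds than are shown below. What is called first, only, known or untested is meant among the compounds shown, and "the series" means these compounds.

In a functional assay on RT-112 cells (Homo sapiens) for antiproliferative activity, read by MTT assay, with a stated time of 72 h (on this read-out higher numbers stand for weaker inhibition of growth and lower numbers for stronger inhibition of growth), compound 1 `COc1cc(NC(=O)Nc2cccc3c(Nc4cc(OC)cc(OC)c4)ncnc23)cc(OC)c1` gives 366 nM, while compound 2 `COc1cc(Nc2ncnc3c(NC(=O)Nc4cc(F)cc(F)c4)cccc23)cc(OC)c1` gives 2630 nM, the higher of the two numbers and so the weaker inhibition of growth. Compound 3 `COc1cc(Nc2ncnc3c(NC(=O)Nc4ccc(F)cc4C(F)(F)F)cccc23)cc(OC)c1` differs from compound 2 at one place: 4-fluoro-2-(trifluoromethyl)phenyl in place of 3,5-difluorophenyl on an amide-type nitrogen. It carries 4-fluoro-2-(trifluoromethyl)phenyl in place of 3,5-difluorophenyl on an amide-type nitrogen. For the measured compounds named here, only one measured step bears on this change: a 7.2-fold higher number from compound 1 to compound 2 (0.86 log units; beyond the scatter), with 3,5-difluorophenyl in place of 3,5-dimethoxyphenyl on that same nitrogen. That modest step shows the number moving with the group at this place, but it involves no trifluoromethyl group and gives no direction for compound 3. Going by these compounds, no step beyond the scatter is therefore expected in this assay, though a move either way remains open. The expected change is a 1.1-fold higher number from compound 2 to compound 3 (0.06 log units; within the scatter). For compound 3 the estimated value is 3000 nM, within an expected range from 1000 nM to 9000 nM.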

Compound 3, concentration for 50% growth inhibition: 2970 nM
The estimate for compound 3 lay 1.0-fold (0.00 log units) above the measured number; the range from low to high includes it.
By their numbers in this assay, from the lowest: compound 1; then compounds 2 and 3 (each within the scatter of the next).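

In this assay, the change to 4-fluoro-2-(trifluoromethyl)phenyl on the amide-type nitrogen gives a 1.1-fold higher number from compound 2 to compound 3 (0.05 log units; within the scatter), so these two fluorine-bearing groups cannot be told apart at this position. The change from 3,5-dimethoxyphenyl to 4-fluoro-2-(trifluoromethyl)phenyl gives an 8.1-fold higher number from compound 1 to compound 3 (0.91 log units; beyond the scatter), a second fluorine-bearing group that leaves the number well short of compound 1, which now has the lowest number of the three by steps beyond the scatter. No measurement bears on why the number moves with the group at this position.

The compounds shown leave open whether the lower number of compound 1 needs both methoxy groups or would survive with a single methoxy group. They also leave open what an amine, a carboxylic acid or a longer alkoxy chain on this phenyl ring would do.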